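A few compounds are considered here, and "the series" means these few. Any claim that something is new, unique, unknown or untested is made for them only; others in the source may bear on it.

Compounds measured so far in the cytotoxicity test:
- compound 1 `Cc1ccc(/C(COc2ccc(Br)cc2)=N\NC(N)=S)cc1`: 13200 nM
- compound 2 `COc1ccc(/C(COc2ccc(Br)cc2)=N\NC(N)=S)cc1`: < 25400 nM
- compound 3 `NC(=S)N/N=C(/COc1ccc(Br)cc1)c1ccc(F)cc1`: < 26200 nM

All three share one core and differ only in the group on the aromatic ring of the thiosemicarbazone side. In an ADME assay on L929 cells (Mus musculus) for cytotoxicity, read by resazurin assay, with a stated time of 96 h (on this read-out lower numbers stand for higher toxicity in this test and higher numbers for lower toxicity in this test), compound 1 gives 13200 nM. For compound 2 the reading in this assay is a limit of the assay, < 25400 nM, and not a number. For compound 3 the reading in this assay is likewise a limit, < 26200 nM. Compound 2 thus stands at a limit, and one further value shown is also a limit. The steps a step that the limit leaves unreadable from compound 1 to compound 2, a step that the limit leaves unreadable from compound 1 to compound 3 and a step that the two limits leave unreadable from compound 2 to compound 3 cannot be sized because the limit of < 25400 nM in this assay, at which 1 of the 3 values shown sits, and the limit of < 26200 nM in this assay, at which 1 of the 3 values shown sits, hide the true numbers.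

Compound 4 `NC(=S)N/N=C(/COc1ccc(Br)cc1)c1ccc(Br)cc1` arises from compound 2 through (bromo in place of methoxy on an aromatic carbon). Going by the values given here, no measured step bears readably on this change, and the values shown all sit in one region, so no step beyond the scatter is expected in this assay. Compound 4 is therefore expected to give about 15000 nM, within 5000 nM to 40000 nM. The step that the limit leaves unreadable from compound 2 to compound 4 implied by this estimate is expected to be small.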

Compound 4, half-maximal cytotoxic concentration: 22600 nM
The estimate for compound 4 lay 1.5-fold (0.18 log units) below the measured number; measured number inside the range.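

Bromo in place of methyl on this aromatic carbon, para to a large group, gives the first step at this position that can be read in this assay: a 1.7-fold higher number from compound 1 to compound 4 (0.23 log units; within the scatter). On these two compounds, then, the exchange of methyl for bromo does not separate them in this test. The steps from compound 2 and from compound 3 to compound 4 cannot be read, since the readings of compound 2 and compound 3 are limits of the assay and not numbers.

As far as these compounds go, how methoxy and fluoro truly compare with bromo here stays open, as only methyl and bromo have numbers at this position. From the compounds shown here alone, it also remains unknown whether an amine or a carboxylic acid on this aromatic carbon would shift the number beyond the scatter.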